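The source may hold more compounds than are shown below. What is called first, only, known or untested is meant among the compounds shown, and "the series" means these compounds.

Compound 1 `CC(=O)Nc1ccc(O)c(C(=O)/C=C/c2ccc(F)cc2)c1` and compound 2 `CC(=O)Nc1ccc(O)c(C(=O)/C=C/c2ccc(C(F)(F)F)cc2)c1` share one core, while compound 3 `CC(=O)Nc1ccc2oc(-c3ccc(F)cc3)cc(=O)c2c1` and compound 4 `CC(=O)Nc1ccc2oc(-c3ccc(C(F)(F)F)cc3)cc(=O)c2c1` share another; the difference between the two cores is not broken down here. In an ADME assay on THP-1 cells (Homo sapiens) for cytotoxicity, read by flow cytometry and propidium iodide staining, with a stated time of 72 h (a lower number here means a stronger inhibitor, a higher number a weaker inhibitor), compound 1 gives 68800 nM, compound 2 gives 15500 nM, and compound 3 gives 22000 nM. Between compound 1 and compound 2 the change is trifluoromethyl in place of fluoro on an aromatic carbon, and it produced a 4.4-fold lower number from compound 1 to compound 2 (0.65 log units; beyond the scatter). Compound 4 carries the same change on its own core, (trifluoromethyl in place of fluoro on an aromatic carbon). Compound 3 sits within the scatter of compound 2 in this assay, and its number lies above that of compound 1 by a margin beyond the scatter. Within the data shown here, only one measured pair shows this change, so the expectation for compound 4 rests on a single step and is held loosely. In this assay the expected step is a 4.0-fold lower number from compound 3 to compound 4 (0.60 log units; beyond the scatter), because the matching step a 4.4-fold lower number from compound 1 to compound 2 (0.65 log units; beyond the scatter) was modest yet beyond the scatter. Compound 4 is therefore estimated at 5500 nM in this assay, with a likely range from 2500 nM to 13000 nM.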

Compound 4, half-maximal inhibitory concentration: 10000 nM
Compound 4: middle estimate off by 1.8-fold (0.26 log units), on the low side; the range from low to high includes it.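

In this assay, putting trifluoromethyl in place of fluoro on the second core gave a 2.2-fold lower number from compound 3 to compound 4 (0.34 log units; beyond the scatter) and so moved the number the same way as on the first core. The two steps do not differ by more than repeated measurements of this kind would allow, so the change carried over from one core to the other in direction and, as far as the scatter can tell, in size: the same change on two cores in this assay, a 4.4-fold lower number (0.65 log units; beyond the scatter) from compound 1 to compound 2 and a 2.2-fold lower number (0.34 log units; beyond the scatter) from compound 3 to compound 4, 2.0-fold (0.30 log units) apart, within the scatter of two such steps. This rests on just one pair of compounds per core in a single cell assay, so it does not show that the step would hold on any further core or in any other test, and it does not explain why the number falls.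

The compounds shown leave open how a chloro, a methoxy or an amine at the same place would compare with fluoro and trifluoromethyl on either core. Going by these compounds, it also remains open whether a carboxylic acid there would follow the same trend on both cores.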